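Swapping methyl for chloro on a nitro-bearing dienone scaffold

The source may hold more compounds than are shown below. What is called first, only, known or untested is meant among the compounds shown, and "the series" means these compounds.

Of the compounds shown here, two have been measured in a functional assay on L1210 cells (Mus musculus) for cytotoxicity, with a stated time of 48 h; a higher number here means a weaker inhibitor, a lower number a stronger inhibitor. Compound 1, `Cc1ccc(/C=C2\CCC/C(=C\c3ccc([N+](=O)[O-])cc3)C2=O)cc1`, gives 8160 nM in this assay. Compound 2, `CN(C)c1ccc(/C=C2\CCC/C(=C\c3ccccc3[N+](=O)[O-])C2=O)cc1`, gives 164000 nM in this assay. Of these two numbers, compound 1 has the lower one, and compound 2 sits well beyond the scatter of repeated measurements from it, so compound 1 is the stronger inhibitor of the pair.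

The step under consideration leads from compound 1 to compound 3, `O=C1/C(=C/c2ccc(Cl)cc2)CCC/C1=C\c1ccc([N+](=O)[O-])cc1`, which has not yet been measured in this assay. The change is small in count: chloro in place of methyl on an aromatic carbon. A methyl leaves and a chloro enters, each a single heavy atom, on an aromatic carbon of a six-membered aromatic ring of carbon only, para to a large group; the shared core is untouched.

Among the measured compounds shown here, no measured pair shows the effect of this exchange. The step from compound 1 to compound 3 is expected to be modest, a 1.5-fold lower number from compound 1 to compound 3 (0.17 log units; within the scatter), and if anything toward a lower number. Compound 3 is therefore estimated at 5500 nM in this assay, within a range from 2000 nM to 16000 nM, because compound 1 gives 8160 nM and the change is confined to one atom.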

Compound 3, half-maximal inhibitory concentration: 9410 nM
Estimate against measurement, compound 3: 1.7-fold (0.23 log units) below; the range from low to high includes it.
By their numbers in this assay, from the lowest: compounds 1 and 3 (each within the scatter of the next); then compound 2.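

In this assay, among the compounds shown here, the exchange of methyl for chloro provides the first comparison in this set of compounds that differ in only one place: a 1.2-fold higher number from compound 1 to compound 3 (0.06 log units; within the scatter). On an aromatic carbon para to a large group, with the shared core and the nitro-bearing side left unchanged, going from 4-methylphenyl to 4-chlorophenyl therefore produces no change that can be told apart from the scatter of the measurement, although this rests on a single pair. Nothing available bears on why this exchange behaves as it does.

The compounds shown leave open whether this tolerance extends beyond these two single-atom groups, for instance to a methoxy group, a carboxylic acid or a longer alkyl chain at the same place. They also leave open how far the result carries over to other substitution on the opposite ring, since compound 2 differs from compound 1 in more than one place and so gives no separate reading of either change.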